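Adding a methoxy group to the cinnamoyl end of quinoline amines

This account rests on a few compounds, and the source may have more. Where it says the series, first, only, none or still open, it means among the compounds named here.

Compound 1 `COc1cc(NC(C)CCCNC(=O)/C=C/c2ccccc2)c2ncccc2c1` and compound 2 `COc1ccc(/C=C/C(=O)NCCCC(C)Nc2cc(OC)cc3cccnc23)cc1` were both tested in an ADME assay on L6 cells (Rattus norvegicus) for cytotoxicity, read by resazurin assay, with a stated time of 70 h; a higher number here means a weaker inhibitor, a lower number a stronger inhibitor. Compound 1 gives 18500 nM. For compound 2 the result is only a limit, > 240000 nM, as set out in the limit of > 240000 nM in this assay, at which 1 of the 3 values shown sits. The change is methoxy in place of hydrogen on an aromatic carbon, and it brought an at least 12-fold higher number from compound 1 to compound 2 (1.11 log units; beyond the scatter). Compound 3 `COc1ccc(/C=C/C(=O)NNC(=O)NCCCC(C)Nc2cc(OC)cc3cccnc23)cc1` gives 3600 nM in this assay; how its core differs from that of compound 1 is not broken down here. Compound 4 `COc1cc(NC(C)CCCNC(=O)NNC(=O)/C=C/c2ccc(OC)c(OC)c2)c2ncccc2c1` is not yet measured. It differs from compound 3 by methoxy in place of hydrogen on an aromatic carbon, the same kind of change as before, though here the entering group sits ortho to a methoxy group and meta to a large group rather than para to a large group. Resting on compound 1 and compound 2 with an at least 12-fold higher number from compound 1 to compound 2 (1.11 log units; beyond the scatter), a smaller rise is expected, a 2.5-fold higher number from compound 3 to compound 4 (0.40 log units; beyond the scatter). Compound 4 is therefore estimated at 9000 nM in this assay.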

Compound 4, half-maximal inhibitory concentration: 37000 nM
Compound 4: the middle estimate sits 4.1-fold (0.61 log units) below what was measured; the measured number falls inside the stated range.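

Adding the methoxy group gave a higher number on both cores in this assay, and on the second core the change is a 10-fold higher number from compound 3 to compound 4 (1.01 log units; beyond the scatter). The direction carried over from one core to the other, but whether the size did remains unsettled: the same change on two cores in this assay, an at least 12-fold higher number (1.11 log units; beyond the scatter) from compound 1 to compound 2 and a 10-fold higher number (1.01 log units; beyond the scatter) from compound 3 to compound 4; the limit leaves it open whether they differ. Compound 2 gives > 240000 nM, which is a limit and not a number.

The compounds shown leave open whether a different group on the same ring, such as a hydroxyl, an amine or a carboxylic acid, would move the number in the same direction. They also leave open whether adding methoxy would give a similar rise on a core with a longer chain.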